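The source may hold more compounds than are shown below. What is called first, only, known or untested is meant among the compounds shown, and "the series" means these compounds.

Measured so far in an ADME assay on J774 cells (Mus musculus) for cytotoxicity; a lower number here means that less compound is needed, a higher number that more compound is needed for the effect:
- Compound 1 `CCCCc1cc2c(=O)c(C(=O)OC)c[nH]c2cc1OCCOc1ccccc1`: > 20000 nM
- Compound 2 `CCCCc1cc2c(=O)c(C(=O)NCC)c[nH]c2cc1OCCOc1ccccc1`: > 20000 nM

Both entries are limits of the assay, not numbers. Compound 2 therefore stands only at a limit, > 20000 nM. The whole data set comes down to the limit of > 20000 nM in this assay, at which 2 of the 2 values shown sit.

Compound 3 `CCCCc1cc2c(=O)c(C(=O)NCCO)c[nH]c2cc1OCCOc1ccccc1` carries (2-hydroxyethyl)amino where compound 2 has ethylamino: hydroxy in place of hydrogen on a saturated chain carbon, two bonds along the chain from an amide-type nitrogen.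

Among the measured compounds shown here, the one measured step that bears on this is a step that the two limits leave unreadable from compound 1 to compound 2, with ethylamino in place of methoxy on a carbonyl carbon. It gives no size to carry over, so no readable step and no direction are expected in this assay. The assay will most likely again report only a limit. The estimated change is a step that the limit leaves unreadable from compound 2 to compound 3. For compound 3 the estimate is 25000 nM, with an expected range from 12000 nM to 50000 nM.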

Compound 3, half-maximal effective concentration: > 20000 nM
Compound 3 was reported as a limit; the forecaster's own chance of this, stated with the estimate: 85%; the middle value lies beyond the limit too.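

In this assay compound 3 gives > 20000 nM, which is a limit of the assay and not a number. Among the compounds shown here, no step among compound 1, compound 2 and compound 3 can be read. The compounds shown leave open whether either change alters cytotoxicity in this assay at all.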